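Ethyl in place of methoxy on the carbonyl of compound 1

The source may report more compounds than this note shows. Statements on the series, on what has been measured and on what is new or still open speak of the compounds shown alone.

Compound 1, `COC(=O)c1ccc(NCc2cncn2Cc2ccc(-c3ccccc3)cc2)cc1-c1ccccc1`: in a toxicity assay on NIH3T3 cells (Mus musculus) for cytotoxicity, read by resazurin assay (on this read-out higher numbers stand for an effect only at larger amounts of compound and lower numbers for an effect already at smaller amounts), compound 1 gives > 1000 nM, a limit of the assay rather than a number.
Compound 2, `COC(=O)c1ccc(NCc2cncn2Cc2cccc(-c3ccccc3)c2)cc1-c1ccccc1`: in this assay compound 2 gives "not determined" (no result reported).
Compound 3, `COC(=O)c1ccc(NCc2cncn2Cc2ccc([N+](=O)[O-])cc2)cc1-c1ccccc1`: in this assay compound 3 gives > 10000 nM, again a limit of the assay.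

Among the compounds with values here, compound 1 therefore stands only at a limit, (the limit of > 1000 nM in this assay, at which 1 of the 3 values shown sits), with no measured number of its own; the one other value shown is also a limit, (the limit of > 10000 nM in this assay, at which 1 of the 3 values shown sits), and the third entry carries no number at all. Within the data shown here, the one step between measured compounds, a step that the two limits leave unreadable from compound 1 to compound 3, concerns nitro in place of phenyl and says nothing readable about size.

Compound 4, `CCC(=O)c1ccc(NCc2cncn2Cc2ccc(-c3ccccc3)cc2)cc1-c1ccccc1`, differs from compound 1 only at the carbonyl: ethyl in place of methoxy on a carbonyl carbon. No measured step bears on this change, so no direction can be read from the data; the shared core has shown effects only at or beyond the limits recorded. Compound 4 is therefore expected to behave much like compound 1, with a step that the limit leaves unreadable from compound 1 to compound 4, and is estimated at 20000 nM (from 3000 nM to 100000 nM), most likely again reported only as a limit.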

Compound 4, half-maximal effective concentration: > 10000 nM
Compound 4 gave a limit, no number; the forecaster's own chance of this, stated with the estimate: 80%; the middle value lies beyond the limit too.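

In this assay, compound 1 and compound 4 both give only limits of the assay, not numbers, and no step can be read between them. The compounds shown leave open whether ethyl in place of methoxy on a carbonyl carbon changes the effect at all, and by how much.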